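Benzyl in Place of Fluorophenyl: Expected Effect on Toxicity

A few compounds are considered here, and "the series" means these few. Any claim that something is new, unique, unknown or untested is made for them only; others in the source may bear on it.

Compound 1 `O=C(Nc1ccc(F)cc1)c1c(NO)cc(-c2ccccc2)oc1=O` was tested in an ADME assay on Huh-7 cells (Homo sapiens) for cytotoxicity, read by a luciferase reporter and WST assay, with a stated time of 3 days; on this read-out higher numbers stand for lower toxicity in this test and lower numbers for higher toxicity in this test. In this assay compound 1 gives only a limit, > 20000 nM, so no number is known for it. Compound 2 `COC(=O)CNC(=O)c1c(NO)cc(-c2ccc(F)cc2)oc1=O`, which shares the same core, also returns a limit in this assay, > 20000 nM. Within the data shown here, every value so far therefore sits at the same edge of the test (the limit of > 20000 nM in this assay, at which 2 of the 2 values shown sit), and nothing yet separates one compound from another. Compound 3 `O=C(NCc1ccccc1)c1c(NO)cc(-c2ccccc2)oc1=O` differs from compound 1 by a single change: benzyl in place of 4-fluorophenyl on an amide-type nitrogen. Among the measured compounds shown here, no step between measured compounds is available to show how such a change moves toxicity, so the expectation rests only on where the known compounds stand. Compound 3 is expected to behave like compound 1, with an estimated step of a number no higher from compound 1 to compound 3 (the limit leaves the size open) no larger than the usual scatter. The estimated value for compound 3 is 20000 nM, between 10000 nM and 40000 nM, and most likely the assay again reports only a limit.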

Compound 3, half-maximal cytotoxic concentration: > 20000 nM
Compound 3 was reported as a limit; the forecaster's own chance of this, stated with the estimate: 85%; the middle value lies on the limit itself.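

No step from compound 1 to compound 3 can be read, because both results are limits and not numbers: the limit of > 20000 nM in this assay, at which 3 of the 3 values shown sit.

The compounds shown leave open whether benzyl in place of 4-fluorophenyl on an amide-type nitrogen changes toxicity at all, and by how much.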